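A Group Swap on a Carbonyl Carbon

The source may report more compounds than this note shows. Statements on the series, on what has been measured and on what is new or still open speak of the compounds shown alone.

Of the compounds shown here, three have numbers so far in a functional assay on HUVEC cells (Homo sapiens), read by BrdU incorporation, with a stated time of 72 h (on this read-out higher numbers stand for weaker inhibition and lower numbers for stronger inhibition), and all three share a similar build. Compound 1 `Cc1ccc2nc(Cl)c(/C=C/C(=O)c3sccc3C)cc2c1` gives 127 nM and compound 3 `Cc1ccc2cc(/C=C/C(=O)c3ccc(I)s3)c(Cl)nc2c1` gives 135 nM in this test, two numbers within the scatter of each other. Compound 2 `Cc1cccc2cc(/C=C/C(=O)c3ccc(I)s3)c(Cl)nc12` gives 284 nM as a higher number, beyond the scatter from compound 1, which therefore sits level with compound 3 at the stronger end of this small set.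

Compound 4 `Cc1ccc2nc(Cl)c(/C=C/C(=O)c3cc(C)sc3C)cc2c1` has 2,5-dimethylthiophen-3-yl in place of 3-methylthiophen-2-yl on a carbonyl carbon and keeps the core of compound 1. For the measured compounds named here, no two tested compounds differ in only one place, so no measured step guides this change. Compound 1 differs from compound 3 in more than one place, yet compound 3 at 135 nM stays within the scatter of compound 1. A step within the scatter is therefore expected in this assay with a slightly higher number as the likelier direction. The expected change is a 1.4-fold higher number from compound 1 to compound 4 (0.15 log units; within the scatter) in this estimate. For compound 4 the estimated value is 180 nM with an expected range from 60 nM to 500 nM in this assay when it is measured.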

Compound 4, half-maximal inhibitory concentration: 229 nM
For compound 4 the middle estimate is 1.3-fold (0.10 log units) below the measured one; the measured number falls inside the stated range.
By their numbers in this assay, from the lowest: compounds 1, 3, 4 and 2 (each within the scatter of the next, the first and the last beyond it).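

For the compounds shown here, this is the first comparison in the set where only one place changes, so the group on the carbonyl carbon can be judged apart from the rest of the molecule: in this assay, putting 2,5-dimethylthiophen-3-yl in place of 3-methylthiophen-2-yl gives a 1.8-fold higher number from compound 1 to compound 4 (0.26 log units; within the scatter) on an unchanged core. Going by these compounds alone, this place therefore takes either thiophene group without a shift that clears the usual scatter, although the single step cannot separate the added methyl from the different point of attachment of the ring. Nothing available explains the size of this step.

The compounds shown carry only thiophene groups on this carbonyl carbon, so how a phenyl ring or a morpholine would read there remains open. On these data alone, it is equally open how an unsubstituted thiophen-2-yl would compare with these two groups.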